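Morpholine sulfonamide in a Vero cell cytotoxicity series

This account rests on a few compounds, and the source may have more. Where it says the series, first, only, none or still open, it means among the compounds named here.

Compound 2 `Cn1nc(C(F)(F)F)cc1C(=O)Nc1ccc(S(=O)(=O)N2CCCCC2C(=O)O)cc1` carries a 2-carboxypiperidin-1-yl group on its sulfonyl sulfur. In an ADME assay on Vero cells (Chlorocebus sabaeus) for cytotoxicity, read by MTT assay (on this read-out higher numbers stand for lower toxicity in this test and lower numbers for higher toxicity in this test), compound 2 reaches only the limit of the assay, > 300000 nM, and no number is known. Compound 1 `Cn1nc(C(F)(F)F)cc1C(=O)Nc1ccc(S(=O)(=O)N2CCCCC2)cc1` bears hydrogen instead of the carboxy group on the saturated ring carbon. In this assay compound 1 likewise stops at the limit, > 300000 nM. The step that the two limits leave unreadable from compound 1 to compound 2 cannot be read because the limit of > 300000 nM in this assay, at which 2 of the 2 values shown sit, holds both values. Compound 3 `Cn1nc(C(F)(F)F)cc1C(=O)Nc1ccc(S(=O)(=O)N2CCOCC2)cc1` is not yet measured. It differs from compound 2 by morpholin-4-yl in place of 2-carboxypiperidin-1-yl on a sulfonyl sulfur. No measured step bears directly on this change; the single step shown concerns a different group and is itself unreadable. With both measured compounds at the limit, compound 3 is expected to remain of low toxicity in this assay, and the step that the limit leaves unreadable from compound 2 to compound 3 is expected to stay within the scatter. Compound 3 is therefore estimated at 400000 nM, within a range of 100000 nM to 1500000 nM, and is most likely to be reported again only as a limit.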

Compound 3, half-maximal cytotoxic concentration: > 300000 nM
Compound 3: only a limit was reported; the forecaster's own chance of this, stated with the estimate: 80%; the middle value lies beyond the limit too.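

Among the compounds shown here, no step among compound 1, compound 2 and compound 3 can be read in this assay, since all three stop at the same limit: the limit of > 300000 nM in this assay, at which 3 of the 3 values shown sit.

The compounds shown leave open how far apart their true values lie in this assay, and whether any change on the sulfonyl sulfur would give a measurable number rather than a limit.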